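The source may hold more compounds than are shown below. What is called first, only, known or untested is meant among the compounds shown, and "the series" means these compounds.

Compound 3 `CCCNC(=O)c1cc(Oc2ccc(NC(=O)c3cc4cccnc4n(-c4ccc(F)cc4)c3=O)cc2)ccn1` gives the lowest number of the three measured compounds in a functional assay on A549 cells (Homo sapiens) for antiproliferative activity, read by MTT assay, with a stated time of 72 h; on this read-out lower numbers stand for stronger inhibition and higher numbers for weaker inhibition; the nearest is compound 2 `CCNC(=O)c1cc(Oc2ccc(NC(=O)c3cc4cccnc4n(-c4ccc(Cl)cc4)c3=O)cc2)ccn1` with 250 nM, the furthest compound 1 `CNC(=O)c1cc(Oc2ccc(NC(=O)c3cc4cccnc4n(-c4ccc(Cl)cc4)c3=O)cc2)ccn1` with 370 nM, against 62 nM for compound 3. Compound 4 `CCCNC(=O)c1cc(Oc2ccc(NC(=O)c3cc4cccnc4n(-c4ccc(Cl)cc4)c3=O)cc2)ccn1` differs from compound 3 by chloro in place of fluoro on an aromatic carbon. Within the data shown here, the only single-point step measured, a 1.5-fold lower number from compound 1 to compound 2 (0.17 log units; within the scatter), concerns the amide-bound chain and not this ring substituent, so no measured step bears directly on the change; compound 2 and compound 3 differ in two places at once, and their values alone cannot separate them. Compound 4 is therefore expected to show a 1.3-fold higher number from compound 3 to compound 4 (0.11 log units; within the scatter), a step not clearly beyond the scatter, giving an estimate of 80 nM in this assay, with a range from 30 nM to 220 nM.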

Compound 4, half-maximal inhibitory concentration: 120 nM
Estimate against measurement, compound 4: 1.5-fold (0.18 log units) below; low and high end bracket the measured number.
By their numbers in this assay, from the lowest: compounds 3 and 4 (each within the scatter of the next); then compounds 2 and 1 (each within the scatter of the next).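

In this assay, chloro in place of fluoro gives a 1.9-fold higher number from compound 3 to compound 4 (0.29 log units; within the scatter), so the two halogens on this aromatic carbon cannot be told apart here. With chloro kept in place, lengthening the chain on the amide nitrogen now has a modest effect, with a 2.1-fold lower number from compound 2 to compound 4 (0.32 log units; beyond the scatter) and a 3.1-fold lower number from compound 1 to compound 4 (0.49 log units; beyond the scatter). Nothing measured here explains these steps.

From the compounds shown here alone, whether a longer chain, such as butyl, would lower the number further remains open. So does the outcome of placing bromo or methoxy on this aromatic carbon.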